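The source may hold more compounds than are shown below. What is called first, only, known or untested is meant among the compounds shown, and "the series" means these compounds.

Measured so far in an assay on HEK293 cells for positive allosteric modulation of metabotropic glutamate receptor 5 (Homo sapiens), read by FLIPR, with a stated time of 1 h; on this read-out lower numbers stand for an effect already at smaller amounts and higher numbers for an effect only at larger amounts of compound:
compound 1 `CCCCN1CCc2nc(C#Cc3ccccc3)sc2C1`: 110 nM
compound 2 `O=C(C1CCCO1)N1CCc2nc(C#Cc3ccccc3)sc2C1`: 790 nM

Among the compounds with values here, compound 2 stands at the higher of the two numbers in this assay; its only neighbour is compound 1, and the one measured step is a 7.2-fold higher number from compound 1 to compound 2 (0.86 log units; beyond the scatter), a modest rise. Compound 3 `CC(C)S(=O)(=O)N1CCc2nc(C#Cc3ccccc3)sc2C1` is the next member: isopropylsulfonyl in place of (oxolan-2-yl)carbonyl on an amine nitrogen in a ring. Within the data shown here, no measured pair compares two such non-alkyl groups on this nitrogen; the step of a 7.2-fold higher number from compound 1 to compound 2 (0.86 log units; beyond the scatter) covers only the exchange of butyl for the carbonyl group and bears on the present change indirectly. With both compound 2 and compound 3 carrying a non-alkyl group at the same place, the expected step is a 1.1-fold lower number from compound 2 to compound 3 (0.05 log units; within the scatter), that is, no change clearly beyond the scatter, though the direction is uncertain. For compound 3 in this assay the estimate is therefore 700 nM, with a range from 200 nM to 2500 nM.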

Compound 3, half-maximal effective concentration: > 10000 nM
Compound 3: only a limit was reported; the forecaster's own chance of this, stated with the estimate: 10%; at least 14-fold (1.15 log units) between middle value and limit.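

The exchange of (oxolan-2-yl)carbonyl for isopropylsulfonyl on this amine nitrogen gives an at least 12-fold higher number from compound 2 to compound 3 (1.10 log units; beyond the scatter), so two non-alkyl groups with the same count of hydrogen-bond acceptors are not interchangeable at this place. Measured against butyl, the change is an at least 90-fold higher number from compound 1 to compound 3 (1.95 log units; beyond the scatter), which makes this nitrogen far less tolerant of exchange than the first step alone suggested. In this assay compound 3 gives only a limit of the assay, not a number, so both steps are lower bounds: the limit of > 10000 nM in this assay, at which 1 of the 3 values shown sits.

The compounds shown do not separate the sulfonyl link from the isopropyl group on it; a methylsulfonyl or an isobutyryl group on this nitrogen would bear on that. As far as these compounds go, whether a benzyl group or an alkyl chain shorter than butyl keeps the number of compound 1 also stays open.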